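A Fluorophenyl Swap Repeated on a Smaller Saturated Ring

The compounds below may be only part of what the source reports. "The series", "measured", "known", "first", "only" and "open" are said of these compounds alone.

Compound 1 `COc1ccc(-n2nc(Sc3ccc(Cl)cc3)cc(CC[C@@H](C)NC(=O)[C@H]3CCNC[C@@H]3c3ccc(F)cc3)c2=O)cc1` and compound 2 `COc1ccc(-n2nc(Sc3ccc(Cl)cc3)cc(CC[C@@H](C)NC(=O)[C@H]3CCNC[C@@H]3c3ccccc3F)c2=O)cc1` share one core and differ only in where fluorine sits on a phenyl ring. In a functional assay with Melanocortin receptor 4 (Homo sapiens) as the target, read by cAMP accumulation (a higher number here means that more compound is needed for the effect, a lower number that less compound is needed), compound 1 gives 110 nM, while compound 2 gives 550 nM; the change 4-fluorophenyl in place of 2-fluorophenyl on a saturated ring carbon produced a 5.0-fold lower number from compound 2 to compound 1 (0.70 log units; beyond the scatter). Compound 3 `COc1ccc(-n2nc(Sc3ccc(Cl)cc3)cc(CC[C@@H](C)NC(=O)[C@H]3CNC[C@@H]3c3ccccc3F)c2=O)cc1` carries the 2-fluorophenyl on a different core, and the difference between the two cores is not broken down here. In this assay compound 3 gives 710 nM. Compound 4 `COc1ccc(-n2nc(Sc3ccc(Cl)cc3)cc(CC[C@@H](C)NC(=O)[C@H]3CNC[C@@H]3c3ccc(F)cc3)c2=O)cc1` has not been measured; it differs from compound 3 by 4-fluorophenyl in place of 2-fluorophenyl on a saturated ring carbon, the same kind of change as before, though here on a five-membered non-aromatic ring with 1 nitrogen rather than a six-membered one. Within the data shown here, because of a 5.0-fold lower number from compound 2 to compound 1 (0.70 log units; beyond the scatter) a comparable gain is anticipated, tempered since only one earlier instance exists. For compound 4 the expected step is a 3.9-fold lower number from compound 3 to compound 4 (0.60 log units; beyond the scatter). Compound 4 is therefore estimated at 180 nM, with a range from 80 nM to 400 nM.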

Compound 4, half-maximal effective concentration: 110 nM
For compound 4 the middle estimate is 1.6-fold (0.21 log units) above the measured one; measured number inside the range.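

In this assay, the swap from 2-fluorophenyl to 4-fluorophenyl gives a 6.5-fold lower number from compound 3 to compound 4 (0.81 log units; beyond the scatter) on the five-membered ring with 1 nitrogen. The step therefore carries over between these two cores, with a size that matches the earlier one: the same change on two cores in this assay, a 5.0-fold lower number (0.70 log units; beyond the scatter) from compound 2 to compound 1 and a 6.5-fold lower number (0.81 log units; beyond the scatter) from compound 3 to compound 4, 1.3-fold (0.11 log units) apart, within the scatter of two such steps. This is only two instances, so it does not show that the step would hold on any further core, and it does not explain why the 4-fluorophenyl compounds need less compound for the effect.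

On these data alone, all four compounds carry a fluorine on this phenyl ring, so it remains open how a chlorine, a methyl group or a plain phenyl ring would compare. As far as these compounds go, the effect of changing the shared groups elsewhere on the molecule, such as the methoxy group, also remains open.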